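From Bromo to Acetyl: One Swap, One Open Number

The source may report more compounds than this note shows. Statements on the series, on what has been measured and on what is new or still open speak of the compounds shown alone.

In an ADME assay on Vero cells (Chlorocebus sabaeus) for cytotoxicity, read by flow cytometry and propidium iodide staining, with a stated time of 72 h (a lower number here means a stronger inhibitor, a higher number a weaker inhibitor), compound 1 `O=S(=O)(c1ccc(C(F)(F)F)cc1)n1cnc2ccccc21` gives 460000 nM and compound 3 `Cc1cc(C)c(C)c(S(=O)(=O)n2cnc3ccccc32)c1C` gives 205000 nM while compound 2 `O=S(=O)(c1ccc(Br)cc1)n1cnc2ccccc21` gives 1190000 nM as the highest of the three numbers. Its gaps to both of the others lie beyond the usual scatter of repeated measurements.

Compound 4 `CC(=O)c1ccc(S(=O)(=O)n2cnc3ccccc32)cc1` has not been measured yet. It differs from compound 2 by acetyl in place of bromo on an aromatic carbon and this carbon sits para to a large group. Going by the values given here, no measured compound carries acetyl, so the data offer only indirect guidance.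

Among the compounds with values here, the one measured step at this place is a 2.6-fold higher number from compound 1 to compound 2 (0.41 log units; beyond the scatter) with bromo in place of trifluoromethyl. That step is modest, yet it is beyond the scatter. Read in reverse, it shows compound 1 without bromo at a lower number, so a modest step downward is expected when compound 2 loses its bromo. The expected move is a 2.4-fold lower number from compound 2 to compound 4 (0.38 log units; beyond the scatter) in this assay and this estimate remains rough. The estimated value for compound 4 is 500000 nM and the expected range runs from 170000 nM to 1400000 nM on this estimate.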

Compound 4, half-maximal inhibitory concentration: 656000 nM
For compound 4 the middle estimate is 1.3-fold (0.12 log units) below the measured one; low and high end bracket the measured number.
By their numbers in this assay, from the lowest: compound 3; then compounds 1, 4 and 2 (each within the scatter of the next, the first and the last beyond it).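

In this assay, acetyl in place of bromo gives a 1.8-fold lower number from compound 2 to compound 4 (0.26 log units; within the scatter). On this aromatic carbon, para to a large group, a swap that brings 3 heavy atoms in place of 1 and adds 1 hydrogen-bond acceptor therefore leaves the number within the scatter. Acetyl in place of trifluoromethyl gives a 1.4-fold higher number from compound 1 to compound 4 (0.15 log units; within the scatter), so acetyl cannot be told apart from either bromo or trifluoromethyl at this position, even though those two groups are separated by a 2.6-fold higher number from compound 1 to compound 2 (0.41 log units; beyond the scatter), a step beyond the scatter. No measurement at hand shows what lies behind these numbers.

Whether an amine or a carboxylic acid on this same carbon would also stay within the scatter of these compounds remains open, and only such a group could show whether this position responds to a more drastic swap. Compound 3 differs from the others in more than one place, so the effect of a single methyl on this carbon also remains an open question.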